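The compounds below may be only part of what the source reports. "The series", "measured", "known", "first", "only" and "open" are said of these compounds alone.

Compound 1, `CCOC(=O)CCCCCOc1cccc(CN(C(=O)c2ccc(-c3ccncc3)cc2)C(C)C)c1`: > 26000 nM
Compound 2, `CCOC(=O)CCCCCOc1cccc(CN(C(=O)c2ccc(-c3cccnc3)cc2)C(C)C)c1`: > 26000 nM
Compound 3, `CCOC(=O)CCCCCOc1cccc(CN(C(=O)c2ccc(-c3cnc(OC)nc3OC)cc2)C(C)C)c1`: > 26000 nM

In an ADME assay on Raji cells (Homo sapiens) for cytotoxicity, read by CellTiter-Glo and resazurin assay, with a stated time of 72 h (on this read-out higher numbers stand for an effect only at larger amounts of compound and lower numbers for an effect already at smaller amounts), compound 3 gives only a limit, > 26000 nM, and not a number. The same holds for the other two: in this assay compound 1 gives a limit, > 26000 nM, and compound 2 gives a limit, > 26000 nM, so all three rest on (the limit of > 26000 nM in this assay, at which 3 of the 3 values shown sit). Compound 4, `CCOC(=O)CCCCCOc1cccc(CN(C(=O)c2ccc(-c3cccc(OC(C)C)c3)cc2)C(C)C)c1`, carries the change (3-isopropoxyphenyl in place of 2,4-dimethoxypyrimidin-5-yl on an aromatic carbon). The steps that touch the position, a step that the two limits leave unreadable from compound 1 to compound 3 and a step that the two limits leave unreadable from compound 2 to compound 3, cannot be read because both ends are limits, so no direction can be taken from them. The account therefore expects compound 4 to lie near the same limit, with a step that the limit leaves unreadable from compound 3 to compound 4, and it estimates compound 4 at 30000 nM, between 10000 nM and 90000 nM.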

Compound 4, half-maximal effective concentration: > 26000 nM
Compound 4: no number, only a limit; the forecaster's own chance of this, stated with the estimate: 70%; the middle value does not contradict the limit.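

Compound 4 gives only a limit in this assay, > 26000 nM. Its steps from compound 1, compound 2 and compound 3 therefore cannot be read. The compounds shown leave open whether these groups differ at all in this read-out, because every value rests on one limit: the limit of > 26000 nM in this assay, at which 4 of the 4 values shown sit.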